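Triazolylmethyl in Place of Arylsulfonyl in a Receptor Antagonist Series

The source may hold more compounds than are shown below. What is called first, only, known or untested is meant among the compounds shown, and "the series" means these compounds.

Compound 1 `Cc1c(Cc2ccccc2S(=O)(=O)c2cccc(Cl)c2)c2c(n1CC(=O)O)CCNC2=O`: 4 nM
Compound 2 `Cc1c(Cc2ccccc2S(=O)(=O)N(C)Cc2ccccc2)c2c(n1CC(=O)O)CCNC2=O`: 26 nM

In a functional assay on CHO.K1 cells for antagonist activity at prostaglandin D2 receptor 2 (Homo sapiens), read by GTPgammaS binding, with a stated time of 1 h (a lower number here means a stronger inhibitor, a higher number a weaker inhibitor), compound 1 gives 4 nM, the lowest of the two numbers. Among the compounds with values here, the only measured step, a 6.5-fold higher number from compound 1 to compound 2 (0.81 log units; beyond the scatter), changes the substituent on the sulfonyl sulfur. Compound 3 `Cc1c(Cc2ccccc2Cn2ccnn2)c2c(n1CC(=O)O)CCNC2=O` differs from compound 1 by (1H-1,2,3-triazol-1-yl)methyl in place of (3-chlorophenyl)sulfonyl on an aromatic carbon, a larger change than the measured one, since the sulfonyl itself leaves. With only compound 1 and compound 2 to lean on, compound 3 is expected to follow the direction of that step and give a 15-fold higher number from compound 1 to compound 3 (1.18 log units; beyond the scatter), a weaker result. Compound 3 is thus estimated at 60 nM, within 10 nM to 400 nM.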

Compound 3, half-maximal inhibitory concentration: 800 nM
The estimate for compound 3 lay 13-fold (1.12 log units) below the measured number; measured number above the stated range.
By their numbers in this assay, from the lowest: compound 1; then compound 2; then compound 3.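

In this assay, (1H-1,2,3-triazol-1-yl)methyl in place of (3-chlorophenyl)sulfonyl gives a 200-fold higher number from compound 1 to compound 3 (2.30 log units; beyond the scatter), whereas the change that kept the sulfonyl gave a 6.5-fold higher number from compound 1 to compound 2 (0.81 log units; beyond the scatter). At this aromatic carbon, ortho to a large group, the sulfonyl and the six-membered aromatic ring of carbon only leave together, so the shift cannot be assigned to either alone. No measurement shown accounts for the shift. Still open, as far as these compounds go, is whether a 3-chlorobenzyl group, which restores the chlorophenyl ring without the sulfonyl, or a 1,2,3-triazole attached directly to the sulfonyl sulfur would recover the lower number.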